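Aryl Swap on the Ring Nitrogen: Compound 2 to Compound 3

This account rests on a few compounds, and the source may have more. Where it says the series, first, only, none or still open, it means among the compounds named here.

Compound 1 `CC1(C)[C@@H]2CC[C@@]1(CS(=O)(=O)N1CCN(c3cc(C(F)(F)F)ccn3)CC1)C(=O)C2`: 25100 nM
Compound 2 `CC1(C)[C@@H]2CC[C@@]1(CS(=O)(=O)N1CCN(c3ccc(C(F)(F)F)cc3)CC1)C(=O)C2`: > 31600 nM

In a functional assay on CHO-K1 cells for antagonist activity at C-X-C chemokine receptor type 3 (Homo sapiens), read by FLIPR and calcium flux (a higher number here means a weaker inhibitor, a lower number a stronger inhibitor), compound 1 gives 25100 nM. Compound 2 returns only a limit, > 31600 nM, not a number. Going by the values given here, the single measured step, an at least 1.2-fold higher number from compound 1 to compound 2 (0.10 log units; that floor lies within the scatter), stays within the scatter, and one of the two values sits at the limit of > 31600 nM in this assay, at which 1 of the 2 values shown sits. Compound 3 `CC1(C)[C@@H]2CC[C@@]1(CS(=O)(=O)N1CCN(c3ncc(C(F)(F)F)cn3)CC1)C(=O)C2` differs from compound 2 by 5-(trifluoromethyl)pyrimidin-2-yl in place of 4-(trifluoromethyl)phenyl on an amine nitrogen in a ring. Among the compounds with values here, no measured step addresses this particular change, so the evidence offers no direction; the writer expects a step of an at least 1.0-fold lower number from compound 2 to compound 3 (0.02 log units; that floor lies within the scatter), not beyond the scatter. Compound 3 is thus estimated at 30000 nM, within 10000 nM to 100000 nM.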

Compound 3, half-maximal inhibitory concentration: 316 nM
Estimate against measurement, compound 3: 95-fold (1.98 log units) above; the measured number lies below the stated range.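

On the amine nitrogen in the ring, the choice of aryl group can move the number far beyond the scatter, which the step between compound 1 and compound 2 did not show. In this assay, 5-(trifluoromethyl)pyrimidin-2-yl in place of 4-(trifluoromethyl)phenyl gives an at least 100-fold lower number from compound 2 to compound 3 (2.00 log units; beyond the scatter), and in place of 4-(trifluoromethyl)pyridin-2-yl it gives a 79-fold lower number from compound 1 to compound 3 (1.90 log units; beyond the scatter). Compound 2 has only a limit, not a number, so its step is a floor: the limit of > 31600 nM in this assay, at which 1 of the 3 values shown sits.

The compounds shown leave open whether the trifluoromethyl group on the pyrimidin-2-yl ring is needed. They also do not say whether a nitrile or a chlorine atom in its place would keep the number this low.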